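The source may report more compounds than this note shows. Statements on the series, on what has been measured and on what is new or still open speak of the compounds shown alone.

Three compounds share one core and differ only in the group carried on its ring oxygen. Compound 1 `COc1ccc(Oc2nc(Nc3ccc(C#N)cc3)nc3ccccc23)cc1` carries a 4-methoxyphenyl there, and in an ADME assay on MT4 cells (Homo sapiens) for cytotoxicity, read by MTT assay, with a stated time of 4 days (on this read-out lower numbers stand for higher toxicity in this test and higher numbers for lower toxicity in this test), compound 1 gives 340000 nM, the highest number of the three. Compound 2 `Cc1cc(Br)c(Oc2nc(Nc3ccc(C#N)cc3)nc3ccccc23)c(Br)c1` gives 25000 nM in this assay, and compound 3 `Cc1cc(Br)cc(Br)c1Oc1nc(Nc2ccc(C#N)cc2)nc2ccccc12` gives 150000 nM. Both changes away from compound 1 lowered the number: a 14-fold lower number from compound 1 to compound 2 (1.13 log units; beyond the scatter) and a 2.3-fold lower number from compound 1 to compound 3 (0.36 log units; beyond the scatter), while a 6.0-fold higher number from compound 2 to compound 3 (0.78 log units; beyond the scatter) separates the two dibromo compounds.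

Compound 4 `N#Cc1ccc(Nc2nc(Oc3ccccc3)c3ccccc3n2)cc1` is not yet measured. It differs from compound 1 as follows: hydrogen in place of methoxy on an aromatic carbon. Going by the values given here, no measured step removes a methoxy; the two measured steps from compound 1 each swap in a larger, bromine-bearing group and lower the number. Removing a small group is a different kind of change, so only a small shift, if any, is expected, with the direction uncertain and a slight lean downward given that both known changes from compound 1 went down. Compound 4 is therefore expected to give about 250000 nM in this assay, between 100000 nM and 500000 nM, meaning an expected step of a 1.4-fold lower number from compound 1 to compound 4 (0.13 log units; within the scatter).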

Compound 4, half-maximal cytotoxic concentration: 370000 nM
Compound 4: the middle estimate sits 1.5-fold (0.17 log units) below what was measured; the range from low to high includes it.
By their numbers in this assay, from the lowest: compound 2; then compound 3; then compounds 1 and 4 (each within the scatter of the next).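

Taking the methoxy off changes almost nothing in this assay, with a 1.1-fold higher number from compound 1 to compound 4 (0.04 log units; within the scatter), so on this ring the methoxy can be replaced by hydrogen without a shift that stands out from the scatter. The plain phenyl thus gives a simple reference point, and the dibromo groups fall below it, with a 2.5-fold higher number from compound 3 to compound 4 (0.39 log units; beyond the scatter) and a 15-fold higher number from compound 2 to compound 4 (1.17 log units; beyond the scatter), which ties the lower numbers in this set to those two groups and not to the loss of the methoxy. Nothing available explains these differences.

As far as these compounds go, whether an amine or a carboxylic acid in that same place would also leave the number unchanged remains open. From the compounds shown here alone, it is also open whether a single bromine on the phenyl would lower the number.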